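The source may hold more compounds than are shown below. What is called first, only, known or untested is meant among the compounds shown, and "the series" means these compounds.

The measured compounds:

Compound 1, `CN1CCC(C(=O)N2Cc3c(NC(=O)C4CCC4)n[nH]c3C2(C)C)CC1`, gives 140 nM in a functional assay on A2780 cells (Homo sapiens) for antiproliferative activity, read by fluorescence, with a stated time of 72 h; on this read-out lower numbers stand for stronger inhibition and higher numbers for weaker inhibition.
Compound 2, `CN1CCC(C(=O)N2Cc3c(NC(=O)c4ccsc4)n[nH]c3C2(C)C)CC1`, gives 140 nM.
Compound 3, `CN1CCC(C(=O)N2Cc3c(NC(=O)c4ccc(Cl)cc4)n[nH]c3C2(C)C)CC1`, gives 120 nM.

All three share one core and differ only in the group on the carbonyl carbon of the amide. The steps between them are small: no change at the digits printed from compound 1 to compound 2 (within the scatter), a 1.2-fold lower number from compound 1 to compound 3 (0.07 log units; within the scatter), and a 1.2-fold lower number from compound 2 to compound 3 (0.07 log units; within the scatter). Compound 3 has the lowest of the three numbers, but both steps leading to it lie within the scatter, so the three compounds cannot be told apart on this read-out; a cyclobutyl, a thiophen-3-yl and a 4-chlorophenyl on that carbonyl carbon give the same result.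

Compound 4, `CN1CCC(C(=O)N2Cc3c(NC(=O)c4ccc(C(F)(F)F)cc4)n[nH]c3C2(C)C)CC1`, is the next step from compound 3. The change is trifluoromethyl in place of chloro on an aromatic carbon. For the measured compounds named here, no measured step covers exactly this exchange, but the three steps that do exist, all at the same carbonyl carbon, show the assay result unmoved by far larger swaps of the whole group. On that basis the expected step of a 1.1-fold higher number from compound 3 to compound 4 (0.03 log units; within the scatter) is none beyond the scatter. Compound 4 is therefore estimated at 130 nM in this assay, within a range from 60 nM to 280 nM.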

Compound 4, half-maximal inhibitory concentration: 60 nM
For compound 4 the middle estimate is 2.2-fold (0.34 log units) above the measured one; measured number inside the range.
By their numbers in this assay, from the lowest: compounds 4, 3, 1 and 2 (each within the scatter of the next, the first and the last beyond it).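

Swapping chloro for trifluoromethyl on the aromatic ring gives a 2.0-fold lower number from compound 3 to compound 4 (0.30 log units; within the scatter) in this assay, so compound 3 and compound 4 still cannot be told apart on this read-out. For the compounds shown here, the new information comes from the wider swaps at the carbonyl carbon: 4-(trifluoromethyl)phenyl in place of cyclobutyl gives a 2.3-fold lower number from compound 1 to compound 4 (0.37 log units; beyond the scatter) and 4-(trifluoromethyl)phenyl in place of thiophen-3-yl gives a 2.3-fold lower number from compound 2 to compound 4 (0.37 log units; beyond the scatter) and these are the first steps at this position to pass beyond the scatter, which shows that the group there can move the number, though only modestly. Nothing measured here accounts for these steps.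

Going by these compounds, whether the number would move further with a nitrile, a methoxy group or a carboxylic acid on that same aromatic carbon stays open, as does what an unsubstituted phenyl would give. The shared core is the same in all four compounds and only one cell assay is shown, so it is also open whether these small steps would hold with a change elsewhere on the core or on another read-out.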